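A few compounds are considered here, and "the series" means these few. Any claim that something is new, unique, unknown or untested is made for them only; others in the source may bear on it.

Measured compounds:
compound 1, `COc1ccc(-c2ssc(=O)c2-c2cc(OC)c(OC)c(OC)c2)cc1` — 134 nM
compound 2, `COc1ccc(-c2ssc(=O)c2-c2cc(OC)c(OC)c(OC)c2)cc1O` — 3110 nM
compound 3, `COc1ccc(-c2ss/c(=N/O)c2-c2cc(OC)c(OC)c(OC)c2)cc1` — 17400 nM

All three were tested in a functional assay on SGC-7901 cells (Homo sapiens) for antiproliferative activity, read by MTT assay, with a stated time of 72 h; on this read-out lower numbers stand for stronger inhibition and higher numbers for weaker inhibition. Compound 1 gives 134 nM, while compound 2, which carries the change (hydroxy in place of hydrogen on an aromatic carbon), gives 3110 nM; the step of a 23-fold higher number from compound 1 to compound 2 (1.37 log units; beyond the scatter) is large. Compound 3 gives 17400 nM, the highest of the three numbers. How the core of compound 3 differs from that of compound 1 is not broken down here.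

The unmeasured compound 4, `COc1ccc(-c2ss/c(=N/O)c2-c2cc(OC)c(OC)c(OC)c2)cc1O`, carries the change hydroxy in place of hydrogen on an aromatic carbon relative to compound 3. For the measured compounds named here, the place described around this change is the same kind of change as the one from compound 1 to compound 2, read word for word, so it is the same kind of change on a different core. Going by the values given here, because the earlier step of a 23-fold higher number from compound 1 to compound 2 (1.37 log units; beyond the scatter) was large, a similarly large upward step is expected here, with the caveat that only one prior example exists and the core differs. The expected step is a 6.9-fold higher number from compound 3 to compound 4 (0.84 log units; beyond the scatter). Compound 4 is therefore estimated at 120000 nM, expected to lie between 35000 nM and 450000 nM.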

Compound 4, half-maximal inhibitory concentration: 200 nM
Compound 4: the middle estimate sits 600-fold (2.78 log units) above what was measured; the whole stated range lies above it.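

In this assay the change from 4-methoxyphenyl to 3-hydroxy-4-methoxyphenyl gives an 87-fold lower number from compound 3 to compound 4 (1.94 log units; beyond the scatter), so on the core of compound 3 the added hydroxy goes with much stronger inhibition. On the core of compound 1 the same change went the other way, so neither its direction nor its size carried over from one core to the other: the same change on two cores in this assay, a 23-fold higher number (1.37 log units; beyond the scatter) from compound 1 to compound 2 and an 87-fold lower number (1.94 log units; beyond the scatter) from compound 3 to compound 4, 2000-fold (3.31 log units) apart, beyond the scatter of two such steps. This shows that, in this series, a step seen on one core cannot simply be transferred to another, but it does not show why the two cores differ, and two cores give no rule for predicting the step on a third.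

The compounds shown leave open whether an amine or a fluorine at the same place on the ring would also move inhibition in opposite directions on the two cores. They also leave open whether the hydroxy on a third core would follow either of these two results.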